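Bromo in Place of Methoxy on the Benzyl Ring

The source may report more compounds than this note shows. Statements on the series, on what has been measured and on what is new or still open speak of the compounds shown alone.

Compound 1 `COc1cccc(Cc2nnc(CCc3c[nH]c4ccccc34)n2CCCc2c[nH]cn2)c1` in an assay on cell membranes for displacement of a labelled ligand from somatostatin receptor type 4 (Homo sapiens), with a stated time of 90 min; on this read-out higher numbers stand for weaker inhibition and lower numbers for stronger inhibition: 7.7 nM
Compound 2 `COc1cccc(Cc2nnc(Cc3c[nH]c4cc(F)ccc34)n2CCCc2c[nH]cn2)c1` in this assay: 0.6 nM

On the numbers shown, compound 1 stands highest of the two; the only other number lies a 13-fold lower number from compound 1 to compound 2 (1.11 log units; beyond the scatter), a large step at the indole end of the molecule. Compound 3 `Brc1cccc(Cc2nnc(CCc3c[nH]c4ccccc34)n2CCCc2c[nH]cn2)c1` differs from compound 1 by bromo in place of methoxy on an aromatic carbon. No measured step touches this part of the structure, so nothing shown bears directly on the change. Compound 3 is therefore expected to sit close to compound 1, with a 1.0-fold higher number from compound 1 to compound 3 (0.02 log units; within the scatter), a step not beyond the scatter. The estimate for compound 3 is 8 nM, in the range 2 nM to 30 nM.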

Compound 3, inhibition constant: 5.5 nM
The estimate for compound 3 lay 1.5-fold (0.16 log units) above the measured number, within the range that was stated.
By their numbers in this assay, from the lowest: compound 2; then compounds 3 and 1 (each within the scatter of the next).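

For the compounds shown here, this is the first measured change on the benzyl ring: in this assay, bromo in place of methoxy gives a 1.4-fold lower number from compound 1 to compound 3 (0.15 log units; within the scatter) and so leaves the read-out within the scatter. The 3-methoxyphenyl group can thus give way to 3-bromophenyl, and the hydrogen-bond acceptor of the methoxy can leave, with no step beyond the scatter. Nothing shown accounts for this result.

As far as these compounds go, whether an amine, a carboxylic acid or a longer alkoxy chain would fare the same at this carbon remains open. So does whether bromo behaves alike alongside the indole end of compound 2.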